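The compounds below may be only part of what the source reports. "The series", "measured", "known", "first", "only" and "open" are said of these compounds alone.

- compound 1 `CC(C)c1ccc(OC(C)(Cc2ccc(Cl)cc2)C(=O)O)cc1` gives 1 mg/kg; 1 mg/kg; 1 mg/kg (3 entries)
- compound 2 `CC(C)c1ccc(OC(C)(Cc2ccc(Cl)cc2)C(=O)NS(=O)(=O)C(F)(F)F)cc1` gives 5 mg/kg
- compound 3 `CC(C)c1ccc(OC(C)(Cc2ccc(Cl)cc2)C(=N)NO)cc1` gives > 10 mg/kg as a limit of the assay

In a functional assay on the whole organism for inhibition, with Rattus norvegicus as the target (on this read-out lower numbers stand for an effect already at smaller amounts and higher numbers for an effect only at larger amounts of compound), compound 2 gives 5 mg/kg and so shows a higher number than compound 1 at 1 mg/kg; 1 mg/kg; 1 mg/kg (3 entries) on the same read-out. Compound 3 stands at > 10 mg/kg and this is a limit. Compound 4 `CCCc1ccc(CC(C)(Oc2ccc(C(C)C)cc2)C(=O)NS(=O)(=O)C(F)(F)F)cc1` keeps everything in compound 2 except one group, with propyl in place of chloro on an aromatic carbon, para to a large group (propyl in place of chloro on an aromatic carbon). Within the data shown here, the only measured step, an at least 2.0-fold higher number from compound 2 to compound 3 (0.30 log units; that floor lies within the scatter), replaces a different group and leaves the chloro untouched, so it does not bear on this change. It also ends on the limit of > 10 mg/kg in this assay, at which 1 of the 3 values shown sits, and gives only a floor. Among the measured compounds shown here, no measured step exists at this place, so the expectation stays close to compound 2 with a wide margin on both sides. The expected outcome is no change at the digits printed from compound 2 to compound 4 (within the scatter) and no step beyond the scatter is expected in this assay. For compound 4 the estimated value is 5 mg/kg with an expected range from 1.5 mg/kg to 15 mg/kg on this read-out.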

Compound 4, dose for half-maximal effect: > 10 mg/kg
Compound 4: a limit, no number (the forecaster's own chance of this, stated with the estimate: 25%); middle value at least 2.0-fold (0.30 log units) from the limit.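

Among these compounds, this is the first reading at this position on the shared core: in this assay, propyl in place of chloro gives an at least 2.0-fold higher number from compound 2 to compound 4 (0.30 log units; that floor lies within the scatter). Compound 4 gives > 10 mg/kg, which is a limit of the assay and not a number. The step therefore holds only a floor that stays within the scatter, so it shows no change beyond the scatter, only that this change leaves the series without a number at this place, and the ceiling of the read-out now bounds more of the series: the limit of > 10 mg/kg in this assay, at which 2 of the 4 values shown sit.

Going by these compounds, how far compound 4 truly lies from compound 2 stays open. Also open, on these data alone, is how an ethyl group, a methoxy group or an amine at this position would read, and how propyl would read alongside the carboxylic acid of compound 1.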